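A Nitrile Gives Way to a Methyl-Oxadiazole

The compounds below may be only part of what the source reports. "The series", "measured", "known", "first", "only" and "open" are said of these compounds alone.

Compound 2 `N#CC1CC(=O)N(c2cnn3c2CN(C(=O)Nc2cc(F)c(F)c(F)c2)C(C2CC2)C3)C1` holds the higher of two numbers in an ADME assay on the whole organism (Mus musculus, strain ICR) for metabolic stability, at a dose of 50 mg/kg by the oral route (a higher number here means that the compound lasts longer, a lower number that the compound disappears faster), giving 4.63 h; compound 1 `O=C1CC(Oc2ncccn2)CN1c1cnn2c1CN(C(=O)Nc1cc(F)c(F)c(F)c1)C(C1CC1)C2` gives 0.95 h. For the measured compounds named here, the only measured step, a 4.9-fold higher number from compound 1 to compound 2 (0.69 log units; beyond the scatter), concerned the same saturated ring carbon. Compound 3 `Cc1nc(C2CC(=O)N(c3cnn4c3CN(C(=O)Nc3cc(F)c(F)c(F)c3)C(C3CC3)C4)C2)no1` differs from compound 2 as follows: 5-methyl-1,2,4-oxadiazol-3-yl in place of cyano on a saturated ring carbon. Because a 4.9-fold higher number from compound 1 to compound 2 (0.69 log units; beyond the scatter) accompanied the loss of a ring-bearing group from this carbon, and a ring group now returns there, a partial reversal is expected, though the two changes are not the same. Compound 3 is therefore estimated at 2.5 h, within 1 h to 6 h, an expected step of a 1.9-fold lower number from compound 2 to compound 3 (0.27 log units; within the scatter).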

Compound 3, half-life: 3.37 h
The estimate for compound 3 lay 1.3-fold (0.13 log units) below the measured number; low and high end bracket the measured number.
By their numbers in this assay, from the lowest: compound 1; then compounds 3 and 2 (each within the scatter of the next).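

In this assay, a 1.4-fold lower number from compound 2 to compound 3 (0.14 log units; within the scatter) shows that the saturated ring carbon can take 5-methyl-1,2,4-oxadiazol-3-yl, with 6 heavy atoms in place of the 2 of cyano, without a step beyond the scatter. A ring on this carbon therefore does not by itself go with the value of compound 1, since a 3.5-fold higher number from compound 1 to compound 3 (0.55 log units; beyond the scatter) separates two ring-bearing groups. Nothing at hand gives a reason for this difference. From the compounds shown here alone, it remains open how an amine or a carboxylic acid on this carbon would fare. Going by these compounds, the role of the methyl on the oxadiazole also stays open.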